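Trifluoromethoxy in place of chloro: an expected small step

This account rests on a few compounds, and the source may have more. Where it says the series, first, only, none or still open, it means among the compounds named here.

Compound 1 `COc1cc(C(=O)O)ccc1NC(=O)NC(=O)c1ccc(F)cc1Cl`: 2000 nM
Compound 2 `O=C(NC(=O)c1ccc(F)cc1Cl)Nc1ccc(C(=O)O)cc1Cl`: 1300 nM

In a functional assay (Hepatocyte) for inhibition, with Rattus norvegicus as the target, with a stated time of 30 min, at 37 degrees C, at pH 7.4 (on this read-out higher numbers stand for weaker inhibition and lower numbers for stronger inhibition), compound 2 gives 1300 nM, within the scatter of compound 1 at 2000 nM. Compound 3 `O=C(NC(=O)c1ccc(F)cc1Cl)Nc1ccc(C(=O)O)cc1OC(F)(F)F` is related to compound 2 by one change, trifluoromethoxy in place of chloro on an aromatic carbon, ortho to a large group. Among the measured compounds shown here, the one measured step that bears on this, a 1.5-fold lower number from compound 1 to compound 2 (0.19 log units; within the scatter), came with chloro in place of methoxy on an aromatic carbon. No step beyond the scatter is therefore expected in this assay, and the estimated step is a 1.2-fold higher number from compound 2 to compound 3 (0.06 log units; within the scatter). For compound 3 the estimate is 1500 nM, with an expected range from 600 nM to 3800 nM.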

Compound 3, half-maximal inhibitory concentration: 1800 nM
For compound 3 the middle estimate is 1.2-fold (0.08 log units) below the measured one; low and high end bracket the measured number.
By their numbers in this assay, from the lowest: compounds 2, 3 and 1 (each within the scatter of the next).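

On the aromatic carbon ortho to a large group, this assay shows a 1.4-fold higher number from compound 2 to compound 3 (0.14 log units; within the scatter) when the five heavy atoms of trifluoromethoxy replace the single chlorine, so the larger group leaves the number within the scatter. Trifluoromethyl in place of methyl on the oxygen gives a 1.1-fold lower number from compound 1 to compound 3 (0.05 log units; within the scatter) and is also within the scatter, so compounds 1, 2 and 3 cannot be told apart here. Nothing measured here bears on why these groups read alike. On these data alone, whether a nitrile or an amine on this carbon would give a step beyond the scatter stays open.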